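Shortening the hydroxyl arm on a weak modulator

The source may report more compounds than this note shows. Statements on the series, on what has been measured and on what is new or still open speak of the compounds shown alone.

Among the measured compounds shown here, compound 1 `COc1ccc(C#Cc2ccc(C(=O)N3CCC(CO)C3)cc2)cc1` is the only compound here with a measured number in a functional assay on TREX cells for negative allosteric modulation of metabotropic glutamate receptor 3 (Rattus norvegicus), read by calcium flux, with a stated time of 2.5 min; on this read-out lower numbers stand for stronger inhibition and higher numbers for weaker inhibition: compound 1 gives 7590 nM. Compound 2 `O=C(c1ccc(C#Cc2ccc3c(c2)OCCO3)cc1)N1CCC[C@@H](CO)C1` differs from compound 1 in more than one place, and in this assay compound 2 reaches only a limit of the assay, > 10000 nM. That reading is the limit of > 10000 nM in this assay, at which 1 of the 2 values shown sits. Compound 3 `COc1ccc(C#Cc2ccc(C(=O)N3CC[C@H](O)C3)cc2)cc1` carries a 3-hydroxypyrrolidin-1-yl in place of 3-(hydroxymethyl)pyrrolidin-1-yl on a carbonyl carbon. For the measured compounds named here, no measured pair shows a change of this kind, so the direction of the step is open, and compound 1 already sits close to the limit of this assay, where a small loss would leave only a limit. The step from compound 1 to compound 3 is expected to be a 1.3-fold higher number from compound 1 to compound 3 (0.12 log units; within the scatter), a modest weakening at the edge of the scatter. Compound 3 is therefore estimated at 10000 nM, between 4000 nM and 25000 nM.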

Compound 3, half-maximal inhibitory concentration: 27500 nM
Beside the measured number, compound 3's estimate is 2.8-fold (0.44 log units) below it, outside the stated range (above it).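

In this assay, the step at this place on a carbonyl carbon now has a measured direction, a 3.6-fold higher number from compound 1 to compound 3 (0.56 log units; beyond the scatter), so the earlier open question is settled for this pair. Putting 3-hydroxypyrrolidin-1-yl in place of 3-(hydroxymethyl)pyrrolidin-1-yl weakens inhibition by more than the usual scatter, even though both groups hold one five-membered non-aromatic ring, 1 hydrogen-bond donor and 1 hydrogen-bond acceptor. Nothing shown explains the loss.

Among the compounds shown here, compound 2 gives > 10000 nM, a limit of the assay, and it differs from compound 1 in more than one place, so no step to it can be read. Still open, going by these compounds, is whether a longer chain, as in 3-(2-hydroxyethyl)pyrrolidin-1-yl, or an amine in place of the hydroxyl would give stronger inhibition than compound 1.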